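The compounds below may be only part of what the source reports. "The series", "measured", "known", "first", "only" and "open" are said of these compounds alone.

Compound 1 `Cc1cccnc1-c1ccc(C(=O)Nc2ccc(C(F)(F)F)cc2)cc1`: 81 nM
Compound 2 `Cc1cccnc1-c1ccc(C(=O)Nc2ccc(C(C)(C)C)cc2)cc1`: 9 nM
Compound 3 `CC(C)(C)c1ccc(NC(=O)c2ccc(-c3ccccn3)cc2)cc1`: 8 nM

In a functional assay for antagonist activity at transient receptor potential cation channel subfamily V member 1 (Rattus norvegicus) (on this read-out lower numbers stand for stronger inhibition and higher numbers for weaker inhibition), compound 3 has the lowest of the three numbers, yet the step of a 1.1-fold lower number from compound 2 to compound 3 (0.05 log units; within the scatter) lies within the usual scatter, so compounds 2 and 3 cannot be told apart; compound 1 stands clearly higher. Compound 4 `CC(C)(C)c1ccc(NC(=O)c2ccc(-c3ncccc3F)cc2)cc1` differs from compound 3 by fluoro in place of hydrogen on an aromatic carbon. Among the compounds with values here, no measured step swaps fluoro for hydrogen. Within the data shown here, the only change at an aromatic carbon of this ring, the step of a 1.1-fold lower number from compound 2 to compound 3 (0.05 log units; within the scatter), was small, whereas the larger step of a 9.0-fold lower number from compound 1 to compound 2 (0.95 log units; beyond the scatter) concerned another ring. A small fluorine at this carbon is therefore expected to shift the number little, with a step of no change at the digits printed from compound 3 to compound 4 (within the scatter) expected. Compound 4 is estimated at 8 nM, within a range from 3 nM to 22 nM.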

Compound 4, half-maximal inhibitory concentration: 1 nM
Beside the measured number, compound 4's estimate is 8.0-fold (0.90 log units) above it; the measured number lies below the stated range.
By their numbers in this assay, from the lowest: compound 4; then compounds 3 and 2 (each within the scatter of the next); then compound 1.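

In this assay, the carbon two atoms from the ring nitrogen turns out to be sensitive to what it carries, even though hydrogen and methyl there could not be told apart: fluoro in place of hydrogen gives an 8.0-fold lower number from compound 3 to compound 4 (0.90 log units; beyond the scatter). Fluoro in place of methyl gives a 9.0-fold lower number from compound 2 to compound 4 (0.95 log units; beyond the scatter), so fluoro stands apart from both groups at this carbon. No measurement at hand accounts for this difference. On these data alone, whether chlorine or an amine at this carbon would match fluoro remains open. So does whether fluoro would bring the same drop with the trifluoromethyl group of compound 1 in place of tert-butyl.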